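Cytotoxicity across ester variants: from compound 3 to compound 4

This account rests on a few compounds, and the source may have more. Where it says the series, first, only, none or still open, it means among the compounds named here.

In an ADME assay on HepG2 2.2.15 cells (Homo sapiens) for cytotoxicity (on this read-out lower numbers stand for higher toxicity in this test and higher numbers for lower toxicity in this test), compound 1 `CC(=O)OCC(=O)OCCc1c(-c2ccccc2Cl)c2cc(Cl)ccc2[nH]c1=O` gives 100000 nM, compound 2 `O=C(OCCc1c(-c2ccccc2Cl)c2cc(Cl)ccc2[nH]c1=O)c1ccco1` gives 98000 nM and compound 3 `O=C(COc1ccccc1)OCCc1c(-c2ccccc2Cl)c2cc(Cl)ccc2[nH]c1=O` gives 81000 nM. These three values lie within the scatter of one another.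

Compound 4 `COc1ccc(/C=C/C(=O)OCCc2c(-c3ccccc3Cl)c3cc(Cl)ccc3[nH]c2=O)cc1` differs from compound 3 by 2-(4-methoxyphenyl)ethenyl in place of phenoxymethyl on a carbonyl carbon, with 2-(4-methoxyphenyl)ethenyl in place of phenoxymethyl on a carbonyl carbon.

Among the compounds with values here, three measured steps bear on this change: a 1.0-fold lower number from compound 1 to compound 2 (0.01 log units; within the scatter), a 1.2-fold lower number from compound 1 to compound 3 (0.09 log units; within the scatter) and a 1.2-fold lower number from compound 2 to compound 3 (0.08 log units; within the scatter). All three stay within the scatter. Within the data shown here, none of the measured compounds carries the entering group, so the expectation is loose. No step beyond the scatter is expected in this assay.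

The expected step is a 1.0-fold lower number from compound 3 to compound 4 (0.01 log units; within the scatter).

Compound 4 is estimated at 80000 nM, with an expected range of 45000 nM to 120000 nM.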

Compound 4, half-maximal cytotoxic concentration: > 1200000 nM
Compound 4 gave a limit, no number (the forecaster's own chance of this, stated with the estimate: 15%); middle value at least 15-fold (1.17 log units) from the limit.
By their numbers in this assay, from the lowest: compounds 3, 2 and 1 (each within the scatter of the next). At a limit, above all of these: compound 4.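

The value of compound 4 in this assay is a limit and not a number: the limit of > 1200000 nM in this assay, at which 1 of the 4 values shown sits. On this carbonyl carbon, 2-(4-methoxyphenyl)ethenyl gives an at least 14-fold higher number from compound 3 to compound 4 (1.17 log units; beyond the scatter), an at least 12-fold higher number from compound 2 to compound 4 (1.08 log units; beyond the scatter) and an at least 12-fold higher number from compound 1 to compound 4 (1.07 log units; beyond the scatter). The position is therefore not flat in this test: acetoxymethyl, furan-2-yl and phenoxymethyl stay within the scatter of one another, whereas the entering group moves the read-out beyond it, towards lower toxicity in this test.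

The compounds shown leave open whether the step follows from the double bond or the methoxy group. Plain 2-phenylethenyl and saturated 2-(4-methoxyphenyl)ethyl would separate the two.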